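The source may report more compounds than this note shows. Statements on the series, on what has been measured and on what is new or still open speak of the compounds shown alone.

Measured in a functional assay on OVCAR-3 cells (Homo sapiens) for inhibition, read by MTT assay, with a stated time of 24 h; a lower number here means a stronger inhibitor, a higher number a weaker inhibitor:
Compound 1 `Cc1cccc(C)c1/C=C/[C@@H]1CCCCN1`: 6.27 ug/mL
Compound 2 `O=[N+]([O-])c1ccc(/C=C/[C@@H]2CCCCN2)cc1`: 1.02 ug/mL
Compound 3 `COc1ccccc1/C=C/[C@@H]1CCCCN1`: 4.78 ug/mL

Compound 2 has the lowest number of the three, which makes it the strongest inhibitor of this small set. Both compound 3 and compound 1 lie beyond the scatter from it.

Compound 4 `COc1ccc(/C=C/[C@@H]2CCCCN2)cc1` differs from compound 2 in one place: methoxy in place of nitro on an aromatic carbon. In words, this is methoxy in place of nitro on an aromatic carbon. For the measured compounds named here, no two measured compounds differ in only one place, so the size of this change has not been observed directly. The best guide is compound 3, which also carries a methoxy group, though at a different place, and gives 4.78 ug/mL. On that basis, a move to a higher number in this assay, beyond the scatter, is expected, meaning a weaker inhibitor. The expected change is a 4.4-fold higher number from compound 2 to compound 4 (0.64 log units; beyond the scatter). For compound 4 the estimated value is 4.5 ug/mL, with an expected range of 2 ug/mL to 10 ug/mL.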

Compound 4, half-maximal inhibitory concentration: 3.31 ug/mL
Compound 4: middle estimate off by 1.4-fold (0.13 log units), on the high side, and the stated range covers the measured number.
By their numbers in this assay, from the lowest: compound 2; then compounds 4, 3 and 1 (each within the scatter of the next).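

In this assay, placing methoxy where nitro stood on the aromatic carbon gives a weaker inhibitor, with a 3.2-fold higher number from compound 2 to compound 4 (0.51 log units; beyond the scatter) as the size of the change. For the compounds shown here, this is the first comparison in the set in which only one place differs, so this part of the difference can now be tied to the swap of these two groups and not to other changes in the structure. It also shows that the group at this position matters for the measured number, although nothing here gives a measured reason for the direction of the change.

From the compounds shown here alone, only nitro and methoxy can be compared at this position, so it remains open how an amine, a carboxylic acid or a chlorine atom would behave there. Going by these compounds, it is also open whether nitro would give a similar gain when attached elsewhere on the aromatic ring.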